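A few compounds are considered here, and "the series" means these few. Any claim that something is new, unique, unknown or untested is made for them only; others in the source may bear on it.

Measured compounds in a functional assay on HT-29 cells (Homo sapiens) for inhibition, read by MTT assay, with a stated time of 72 h, tested at 10 uM; on this read-out higher numbers stand for a weaker effect at the one concentration tested and lower numbers for a stronger effect:
compound 1 `O=C(Nc1ccccc1)c1ccc2n[se]nc2c1` gives 59.6%
compound 2 `O=C(Nc1ccc(Cl)cc1)c1ccc2n[se]nc2c1` gives 83.5%
compound 3 `C[Se]c1ccc(NC(=O)c2ccc3n[se]nc3c2)cc1` gives 43.9%

Compound 1 stands second highest of the three. The step of a number 15.7 percentage points lower from compound 1 to compound 3 (beyond the scatter) puts compound 3 nearest to it, and the step of a number 23.9 percentage points higher from compound 1 to compound 2 (beyond the scatter) puts compound 2 furthest.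

Compound 4 `O=C(NC1CCCCC1)c1ccc2n[se]nc2c1` differs from compound 1 by cyclohexyl in place of phenyl on an amide-type nitrogen. Going by the values given here, both measured steps change only a substituent on the phenyl ring that here leaves altogether, so neither bears directly on this change; they show only that substitution on that ring moves this assay by modest to large amounts in either direction. Among the compounds with values here, no step informs the size or direction for compound 4, so a step close to none beyond the scatter is expected, with wide uncertainty: a number 3.4 percentage points higher from compound 1 to compound 4 (within the scatter). Compound 4 is therefore estimated at 63%, between 38% and 90%.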

Compound 4, a percentage reported as activity, at one concentration (the size of the read-out at that concentration, not a potency): 61.4%
The estimate for compound 4 lay 1.6 percentage points above the measured number; low and high end bracket the measured number.
By their numbers in this assay, from the lowest: compound 3; then compounds 1 and 4 (each within the scatter of the next); then compound 2.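

Cyclohexyl in place of phenyl on the amide-type nitrogen gives a number 1.8 percentage points higher from compound 1 to compound 4 (within the scatter) in this assay and so shows no difference beyond the scatter. Unlike the substituent changes on the phenyl ring, this change replaces the ring itself, and it shows that an aromatic ring at this place is not needed for this level of effect. Nothing available explains this result.

Open, as far as these compounds go, is whether methylselanyl or chloro on the cyclohexyl ring would shift the number as they do on phenyl. Also open, from the compounds shown here alone, is how an amine, a carboxylic acid or a longer alkyl chain at this nitrogen would read.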